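This account rests on a few compounds, and the source may have more. Where it says the series, first, only, none or still open, it means among the compounds named here.

Compound 1 `COC(=O)c1c(F)cccc1-c1ccc(CCc2ncc(CC(C)(C)C)n2CCC(=O)O)cc1` gives 1 nM in an assay on cells for agonist activity at Bombesin receptor subtype-3 (Homo sapiens), read by HTRF and inositol phosphate accumulation, with a stated time of 1 h (on this read-out higher numbers stand for an effect only at larger amounts of compound and lower numbers for an effect already at smaller amounts), the lowest of the two numbers in hand. Compound 2 `COC(=O)c1c(F)cccc1-c1ccc(CCc2ncc(CC(C)(C)C)n2Cc2ccc(C(=O)O)cc2)cc1` gives 3 nM in this assay, and the shift is a 3.0-fold higher number from compound 1 to compound 2 (0.48 log units; beyond the scatter), brought about by a 4-carboxyphenyl in place of carboxymethyl on a saturated chain carbon bound to an aromatic nitrogen. Compound 3 `COC(=O)c1c(F)cccc1-c1ccc(CCc2ncc(CC(C)(C)C)n2CCNS(C)(=O)=O)cc1` has not been measured; it differs from compound 1 in that (methanesulfonamido in place of carboxy on a saturated chain carbon, two bonds along the chain from an aromatic nitrogen), on a saturated chain carbon, two bonds along the chain from an aromatic nitrogen. Among the measured compounds shown here, no measured step exchanges the carboxy group itself; the step from compound 1 to compound 2 only moves it onto a different carrier, and it cost a modest amount. With the acid group itself now gone from compound 3, the expectation is a loss of similar or somewhat larger size rather than a gain, so the step is estimated as a 4.0-fold higher number from compound 1 to compound 3 (0.60 log units; beyond the scatter). On that basis compound 3 is expected to give about 4 nM in this assay, with a likely range from 1 nM to 20 nM.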

Compound 3, half-maximal effective concentration: 11 nM
Estimate against measurement, compound 3: 2.8-fold (0.44 log units) below; low and high end bracket the measured number.
By their numbers in this assay, from the lowest: compound 1; then compound 2; then compound 3.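

Exchanging the carboxy group itself for methanesulfonamido, rather than moving it onto another carrier, produces a large step in this assay (an 11-fold higher number from compound 1 to compound 3 (1.04 log units; beyond the scatter)), whereas the change from 2-carboxyethyl to the 4-carboxyphenyl-bearing side chain had been only modest. Compound 3 also stands apart from the other acid-bearing compound (a 3.7-fold higher number from compound 2 to compound 3 (0.56 log units; beyond the scatter)), so both carboxy compounds shown have lower numbers than the methanesulfonamido compound, and no compound here goes against that order, although compound 3 still gives a clear reading (11 nM). The data offer no measured basis for explaining the size of either step.

Three compounds cannot show whether the step follows from losing the carboxy group or from what replaces it, since a carboxamide, a tetrazole or a primary amine on the same saturated chain carbon would be needed to separate the two. Going by these compounds, it also remains open whether methanesulfonamido would behave the same way on a longer chain or on the benzyl-type carrier of compound 2.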